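Fluoro on an Aromatic Carbon, Tried on a Second Core

This account rests on a few compounds, and the source may have more. Where it says the series, first, only, none or still open, it means among the compounds named here.

Compound 1 `O=c1c(C2N=C(c3ccccc3)SS2)coc2cc(Cl)ccc12` carries a chloro group on its core. In a functional assay on HEp-2 cells (Homo sapiens) for inhibition, read by sulforhodamine B assay, with a stated time of 48 h (a lower number here means a stronger inhibitor, a higher number a weaker inhibitor), compound 1 gives > 100000 nM, which is a limit of the assay and not a number. Compound 2 `O=c1c(C(=S)Nc2ccccc2)coc2ccccc12` has a core whose difference from that of compound 1 is not broken down here. In this assay compound 2 gives > 100000 nM, again only a limit. Compound 3 `O=c1c(C(=S)Nc2ccccc2)coc2ccc(F)cc12` differs from compound 2 by fluoro in place of hydrogen on an aromatic carbon. In this assay compound 3 gives > 100000 nM, also a limit. The step from compound 2 to compound 3 is thus a step that the two limits leave unreadable from compound 2 to compound 3, and what can be said of it rests on (the limit of > 100000 nM in this assay, at which 3 of the 3 values shown sit).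

Compound 4 `O=c1c(C2N=C(c3ccccc3)SS2)coc2cc(Cl)c(F)cc12` has not been measured. It differs from compound 1 by fluoro in place of hydrogen on an aromatic carbon, the same kind of change as that from compound 2 to compound 3, though here the fluoro enters ortho to a chloro group. Because the limit of > 100000 nM in this assay, at which 3 of the 3 values shown sit, holds for every compound shown, compound 4 is expected to remain there: the estimate for compound 4 is 100000 nM, between 30000 nM and 300000 nM. The expected step from compound 1 to compound 4 is a number no higher from compound 1 to compound 4 (the limit leaves the size open), resting on the unreadable step that the two limits leave unreadable from compound 2 to compound 3.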

Compound 4, half-maximal inhibitory concentration: 97600 nM
For compound 4 the middle estimate is 1.0-fold (0.01 log units) above the measured one; low and high end bracket the measured number.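

In this assay, fluoro in place of hydrogen on an aromatic carbon, ortho to a chloro group, gives an at least 1.0-fold lower number from compound 1 to compound 4 (0.01 log units; that floor lies within the scatter), so on the core of compound 1 the change comes with a number that can be read, while the floor of the step does not establish any real gain in potency. The same change on the core of compound 2 cannot be read, as both ends of that step are limits, and so the data do not show whether the change has the same size on the two cores. This reading across cores rests on very little: the limit of > 100000 nM in this assay, at which 3 of the 4 values shown sit.

The compounds shown leave open whether an amine or a carboxylic acid in place of the chloro group on the core of compound 4 would give a number well clear of that limit. Also open, on these data alone, is whether fluoro on another aromatic carbon of the core of compound 1 would give a readable number at all.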